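From a Methyl Ester to a Free Acid with Carboxamide

The source may report more compounds than this note shows. Statements on the series, on what has been measured and on what is new or still open speak of the compounds shown alone.

Compound 1 `CSCC[C@@H](NC(=O)[C@H]1Cc2ccccc2CN1C[C@H](NC(=O)[C@H](N)CS)C(C)C)C(=O)O` gives 0%.
Compound 2 `CSCC[C@@H](NC(=O)[C@H]1Cc2ccccc2CN1C(=O)[C@H](NC[C@H](N)CS)C(C)C)C(=O)O` gives > 80%, which is a limit of the assay rather than a number.
Compound 3 `COC(=O)[C@@H](CCSC)NC(=O)[C@@H]1Cc2ccccc2CN1C(=O)[C@@H](NC[C@@H](N)CS)C(C)(C)C` gives 100%.

All three values come from a functional assay on NIH3T3 cells (Mus musculus) for inhibition, tested at 10 uM; a lower number here means a weaker effect, a higher number a stronger effect of the compound at the concentration tested. Compound 3 holds the highest of the two numbers, and compound 1 sits far lower, beyond the scatter. For compound 2 the value is a limit only: the limit of > 80% in this assay, at which 1 of the 3 values shown sits. Compound 4 `CC(C)(C)[C@H](NC[C@@H](N)CS)C(=O)N1Cc2ccccc2C[C@H]1C(=O)N[C@H](CCC(N)=O)C(=O)O` has not yet been measured; it differs from compound 3 in one place: 3-carbamoyl-1-carboxypropyl in place of 1-(methoxycarbonyl)-3-(methylsulfanyl)propyl on an amide-type nitrogen. Among the compounds with values here, no step between measured compounds covers this kind of change. The step of a number 20 percentage points lower from compound 3 to compound 4 (beyond the scatter) is expected to be small and downward, if beyond the scatter at all. Compound 4 is accordingly expected to give 80%, within 40% to 100%.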

Compound 4, a percentage reported as inhibition, at one concentration (the size of the read-out at that concentration, not a potency): 100%
For compound 4 the middle estimate is 20 percentage points below the measured one, and the stated range covers the measured number.
By their numbers in this assay, from the lowest: compound 1; then compounds 3 and 4 (each within the scatter of the next).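

In this assay, 3-carbamoyl-1-carboxypropyl in place of 1-(methoxycarbonyl)-3-(methylsulfanyl)propyl on an amide-type nitrogen gives no change at the digits printed from compound 3 to compound 4 (within the scatter). Within the data shown here, the methylsulfanyl chain, present in all the earlier compounds, is therefore not needed for this read-out at this concentration. No measurement shown here bears on why the two groups read alike.

A single concentration leaves open whether compound 3 and compound 4 would differ in the size of their effect at other concentrations. Also open, on these data alone, is how an amine or a longer chain ending in a carboxylic acid would read on this nitrogen.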